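This account rests on a few compounds, and the source may have more. Where it says the series, first, only, none or still open, it means among the compounds named here.

Measured in an ADME assay on microsomes from liver (Homo sapiens) for metabolic stability, read by LC-MS, with a stated time of 10 min, tested at 0.5 uM (a higher number here means that more of the compound is left, a lower number that less of the compound is left), so far:
- compound 1 `c1ccc2c(c1)CN[C@H](CN(CCCN1CCNCC1)[C@H]1CCCc3cccnc31)C2` gives 99% 
- compound 2 `c1ccc2c(c1)CN[C@@H](CN(CCCN1CCNCC1)[C@H]1CCCc3cccnc31)C2` gives 100% 
- compound 3 `c1cnc2c(c1)CN[C@@H](CN(CCCN1CCNCC1)[C@H]1CCCc3cccnc31)C2` gives 79% 

Compound 3 stands lowest of the three, beyond the scatter from compound 1 and compound 2. Compound 4 `c1cnc2c(c1)CCC[C@@H]2N(CCCN1CCNCC1)Cc1nc2ccccc2[nH]1` differs from it by one change (a group of 9 heavy atoms (7 carbon, 2 nitrogen; one five-membered aromatic ring with 2 hetero atoms, one six-membered aromatic ring of carbon only) in place of a group of 10 heavy atoms (8 carbon, 2 nitrogen; one six-membered non-aromatic ring with 1 hetero atom, one six-membered aromatic ring with 1 hetero atom), on a saturated chain carbon bound to an amine nitrogen) that brings in 1H-benzimidazol-2-yl. Two measured steps altered the group at this place (a number 20 percentage points lower from compound 1 to compound 3 (beyond the scatter)) and (a number 21 percentage points lower from compound 2 to compound 3 (beyond the scatter)), both modest and both downward. The step (a number 1 percentage points higher from compound 1 to compound 2 (within the scatter)) lies within the scatter and reflects configuration only (the fact that compounds 1 and 2 differ only in the configuration as drawn), so it bears little on this change. The entering group holds a six-membered aromatic ring of carbon only, as does the group in compound 1 (99%), so a small rise is expected, smaller than those two modest steps. The expected step is (a number 9 percentage points higher from compound 3 to compound 4 (within the scatter)) in this assay. Compound 4 is estimated at 88% (expected range 68% to 100%) .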

Compound 4, percent of the compound remaining: 63%
Compound 4: the middle estimate sits 25 percentage points above what was measured; measured number below the stated range.
By their numbers in this assay, from the lowest: compound 4; then compound 3; then compounds 1 and 2 (each within the scatter of the next).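

In this assay, the group on the saturated chain carbon bound to an amine nitrogen can lower the number further: a number 16 percentage points lower from compound 3 to compound 4 (beyond the scatter). A six-membered aromatic ring of carbon only therefore does not keep the number high by itself. Replacing 1,2,3,4-tetrahydroisoquinolin-3-yl with 1H-benzimidazol-2-yl gives two large steps, a number 36 percentage points lower from compound 1 to compound 4 (beyond the scatter) and a number 37 percentage points lower from compound 2 to compound 4 (beyond the scatter), which count as one finding because of how their starting compounds relate: the fact that compounds 1 and 2 differ only in the configuration as drawn

From the compounds shown here alone, it remains open whether the fall goes with the five-membered aromatic ring or with the loss of the non-aromatic ring. A benzoxazol-2-yl group or an open-chain amine at this place would help separate the two.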